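Replacing Benzyl with 2-Methoxyphenyl on the Amine Nitrogen

The source may report more compounds than this note shows. Statements on the series, on what has been measured and on what is new or still open speak of the compounds shown alone.

Of the compounds shown here, three sharing one core have been measured in a functional assay on MCF7 cells (Homo sapiens) for inhibition, read by sulforhodamine B assay; on this read-out higher numbers stand for weaker inhibition and lower numbers for stronger inhibition. Compound 1 `O=C1C(Nc2cccc(Cl)c2)=CC(=O)c2c1nc1n2[C@H]2OC[C@@H](O)[C@H]2OC1` gives 2970 nM. Compound 2 `O=C1C=C(NCc2ccccc2)C(=O)c2c1nc1n2[C@H]2OC[C@@H](O)[C@H]2OC1` reaches only the limit of the assay, > 8000 nM, so no number is known for it. Compound 3 `O=C1C(N2CCCC2)=CC(=O)c2c1nc1n2[C@H]2OC[C@@H](O)[C@H]2OC1` likewise reaches only a limit, > 16000 nM. Within the data shown here, the one step within the set, an at least 5.3-fold higher number from compound 1 to compound 3 (0.73 log units; beyond the scatter), is at least modest and points toward weaker inhibition; it rests on (the limit of > 16000 nM in this assay, at which 1 of the 3 values shown sits). Compound 2 itself stands at the limit of > 8000 nM in this assay, at which 1 of the 3 values shown sits.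

Compound 4 `COc1ccccc1NC1=CC(=O)c2nc3n(c2C1=O)[C@H]1OC[C@@H](O)[C@H]1OC3` differs from compound 2 in one place: 2-methoxyphenyl in place of benzyl on an amine nitrogen. Among the measured compounds shown here, no measured step covers this exact change. The values of compound 1 and compound 2 show an arylamino group sitting at a lower number than a benzylamino group, and compound 4 carries an arylamino group. The step from compound 2 to compound 4 is therefore expected to lower the number, an at least 1.7-fold lower number from compound 2 to compound 4 (0.24 log units; that floor lies within the scatter), though a further limit cannot be excluded. In this assay compound 4 is estimated at 4500 nM, within 1500 nM to 14000 nM.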

Compound 4, half-maximal inhibitory concentration: > 4000 nM
Compound 4: only a limit was reported; the forecaster's own chance of this, stated with the estimate: 30%; the middle value does not contradict the limit.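

In this assay compound 4 gives only a limit, > 4000 nM. Compound 2 also stands at a limit, so no step can be read between compound 2 and compound 4. As far as these compounds go, whether 2-methoxyphenyl in place of benzyl on the amine nitrogen changes inhibition, and in which direction, stays open.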